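Fluoro added to compound 2 at a second ring position

The compounds below may be only part of what the source reports. "The series", "measured", "known", "first", "only" and "open" are said of these compounds alone.

Measured compounds, in a functional assay on M14 cells (Homo sapiens) for antiproliferative activity, with a stated time of 72 h; a lower number here means a stronger inhibitor, a higher number a weaker inhibitor:
Compound 1 `C=CC[C@H]1C[C@]2([C@@H](C)Cc3ccc(OC)cc3)OCOC2=CC1=O` gives 20 nM.
Compound 2 `C=CC[C@H]1C[C@]2([C@@H](C)Cc3ccc(OC)c(C)c3)OCOC2=CC1=O` gives 410 nM.
Compound 3 `C=CC[C@H]1C[C@]2([C@@H](C)Cc3ccc(OC)c(F)c3)OCOC2=CC1=O` gives 8 nM.

Compound 2 stands highest of the three numbers in this assay: the step of a 21-fold higher number from compound 1 to compound 2 (1.31 log units; beyond the scatter) is large, and the step of a 51-fold lower number from compound 2 to compound 3 (1.71 log units; beyond the scatter) is larger still. Compound 4 `C=CC[C@H]1C[C@]2([C@@H](C)Cc3cc(C)c(OC)cc3F)OCOC2=CC1=O` differs from compound 2 by fluoro in place of hydrogen on an aromatic carbon.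

Within the data shown here, only one measured step is the same kind of change: a 2.5-fold lower number from compound 1 to compound 3 (0.40 log units; beyond the scatter), a modest lowering, though there the fluoro entered at the position where compound 2 carries its methyl, not at the position concerned here. The step of a 51-fold lower number from compound 2 to compound 3 (1.71 log units; beyond the scatter) exchanges the methyl itself and does not bear directly on adding a fluoro while the methyl stays. So the expectation for compound 4 rests on a single, modest precedent at a different position, with the methyl of compound 2 retained.

Compound 4 is therefore expected to give a number somewhat lower than that of compound 2, estimated at 250 nM in this assay, with a range from 80 nM to 800 nM. The expected step is a 1.6-fold lower number from compound 2 to compound 4 (0.21 log units; within the scatter).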

Compound 4, half-maximal inhibitory concentration: 230 nM
The estimate for compound 4 lay 1.1-fold (0.04 log units) above the measured number; measured number inside the range.
By their numbers in this assay, from the lowest: compound 3; then compound 1; then compounds 4 and 2 (each within the scatter of the next).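

In this assay, fluoro in place of hydrogen on the aromatic carbon ortho to a large group, para to a methyl group and meta to a methoxy group gives a 1.8-fold lower number from compound 2 to compound 4 (0.25 log units; within the scatter), so at this position the exchange produces no change that stands clear of the scatter. The earlier compounds shown here showed this exchange only at a different ring position and on a core without the methyl, and the new step shows that the same change on a second core gives a step that cannot be told apart from the first: the same change on two cores in this assay, a 2.5-fold lower number (0.40 log units; beyond the scatter) from compound 1 to compound 3 and a 1.8-fold lower number (0.25 log units; within the scatter) from compound 2 to compound 4, 1.4-fold (0.15 log units) apart, within the scatter of two such steps. Fluoro at this position, with the methyl kept, gives nothing on the scale of a 21-fold higher number from compound 1 to compound 2 (1.31 log units; beyond the scatter), the step that came with the methyl.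

The compounds shown leave open what fluoro at this position does on the core of compound 1, where no methyl is present, and on the core of compound 3, which already carries a fluoro. They also leave open how chloro, a hydroxyl group or an amine would fare on this same aromatic carbon.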